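A Chloro Swap in a Narrow Series

The source may report more compounds than this note shows. Statements on the series, on what has been measured and on what is new or still open speak of the compounds shown alone.

In a functional assay on BGC-823 cells (Homo sapiens) for inhibition, read by CCK-8 assay, with a stated time of 48 h (a lower number here means a stronger inhibitor, a higher number a weaker inhibitor), compound 1 `COc1ccc(C2=NN(C3=NC(c4ccccc4)CS3)C(c3cccc4ccccc34)C2)cc1` gives 9510 nM, compound 2 `COc1ccc(C2=NN(C3=NC(c4ccccc4)CS3)C(c3ccc4ccccc4c3)C2)cc1` gives 7250 nM and compound 3 `COc1ccc(C2=NN(C3=NC(=O)CS3)C(c3cccc4ccccc34)C2)cc1` gives 8210 nM, so compound 2 stands within the scatter of both others. Compound 4 `Clc1ccc(C2=NN(C3=NC(c4ccccc4)CS3)C(c3ccc4ccccc4c3)C2)cc1` differs from compound 2 as 4-methoxyphenyl to 4-chlorophenyl, with chloro in place of methoxy on an aromatic carbon. Among the measured compounds shown here, no measured step touches this place. For the measured compounds named here, the only steps available elsewhere on the molecule are a 1.3-fold lower number from compound 1 to compound 2 (0.12 log units; within the scatter) and a 1.2-fold lower number from compound 1 to compound 3 (0.06 log units; within the scatter), both within the scatter. No change beyond the scatter is therefore expected in this assay, although the data cannot exclude one. The expected step is a 1.2-fold lower number from compound 2 to compound 4 (0.08 log units; within the scatter). Compound 4 is estimated at 6000 nM, with an expected range of 2500 nM to 13000 nM.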

Compound 4, half-maximal inhibitory concentration: 14600 nM
For compound 4 the middle estimate is 2.4-fold (0.39 log units) below the measured one, outside the stated range (above it).
By their numbers in this assay, from the lowest: compounds 2, 3, 1 and 4 (each within the scatter of the next).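

Among the compounds shown here, the earlier compounds all carried 4-methoxyphenyl, so this pair gives the only reading of this position: in this assay, chloro in place of methoxy gives a 2.0-fold higher number from compound 2 to compound 4 (0.30 log units; within the scatter). On this core, the assay therefore does not separate the two groups at this aromatic carbon. No available evidence bears on this result.

On these data alone, whether an amine or a carboxylic acid at this place would move the number beyond the scatter remains open. Also open, as far as these compounds go, is whether the same swap would read alike on the core of compound 1 or compound 3.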